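Hydroxy for cyano on a pyrazolyl azaindole scaffold

The compounds below may be only part of what the source reports. "The series", "measured", "known", "first", "only" and "open" are said of these compounds alone.

Measured compounds:
Compound 1, `Cn1cc(-c2cnc3c(c2)c(-c2cccc(C#N)c2)cn3C)cn1`: 3000 nM
Compound 2, `Cc1c(-c2cnn(C)c2)cnc2[nH]cc(-c3cccc(C#N)c3)c12`: 600 nM
Compound 3, `Cn1cc(-c2cnc3[nH]cc(-c4ccc(C#N)cc4)c3c2)cn1`: 2000 nM

Of the compounds shown here, three sharing a common core have been measured in a physicochemical assay for solubility, read by LC-MS, in phosphate buffer, measured as thermodynamic solubility, with a stated time of 24 h, at pH 7.4; on this read-out higher numbers stand for higher solubility and lower numbers for lower solubility. Compound 1 gives 3000 nM in this assay, compound 2 gives 600 nM and compound 3 gives 2000 nM. Compound 3 stands second highest of the three numbers. Its nearest neighbour is compound 1, whose value lies within the scatter of repeated measurements, so the two cannot be told apart on these data. Compound 2 is the furthest from compound 3, with a lower number that falls beyond the scatter.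

The next compound to be measured is compound 4, `Cn1cc(-c2cnc3[nH]cc(-c4ccc(O)cc4)c3c2)cn1`. It differs from compound 3 in one place: hydroxy in place of cyano on an aromatic carbon. Going by the values given here, no step between two measured compounds in this set is of this kind, so the expectation for compound 4 rests on compound 3 alone and on the nature of the change, a hydroxy group entering where a cyano group leaves, on an aromatic carbon of a six-membered aromatic ring of carbon only.

The author expects the step of a 2.0-fold higher number from compound 3 to compound 4 (0.30 log units; within the scatter) in this assay to be upward and of modest size, near the edge of the scatter. Compound 4 is therefore estimated at 4000 nM, with a range from 1500 nM to 12000 nM.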

Compound 4, solubility: < 3000 nM
Compound 4 gave a limit, no number (the forecaster's own chance of this, stated with the estimate: 5%); middle value at least 1.3-fold (0.12 log units) from the limit.
By their numbers in this assay, from the lowest: compound 2; then compounds 3 and 1 (each within the scatter of the next).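

In this assay compound 4 gives < 3000 nM, which is a limit of the assay and not a number. No size or direction can be read for the step between compound 3 and compound 4. The compounds shown leave open whether hydroxy in place of cyano on an aromatic carbon changes the number in this assay at all, and by how much.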